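Chloro to Methyl on the Amide Aryl Ring

The source may report more compounds than this note shows. Statements on the series, on what has been measured and on what is new or still open speak of the compounds shown alone.

In a functional assay on A549 cells (Homo sapiens) for cytotoxicity, read by MTT assay, with a stated time of 72 h (on this read-out higher numbers stand for weaker inhibition and lower numbers for stronger inhibition), compound 1 `O=C(Nc1nnc(-c2ccc(O)c(O)c2)s1)c1ccc(Cl)cc1` gives 14600 nM, the top of the three numbers shown, though its gaps to the other two lie within the scatter. Compound 2 `O=C(COc1ccccc1)Nc1nnc(-c2cccc(O)c2O)s1` gives 10500 nM and compound 3 `O=C(Nc1nnc(-c2cccc(O)c2O)s1)c1ccc(Cl)cc1` gives 9500 nM. For the measured compounds named here, the single step between measured compounds that differ in one place, a 1.1-fold lower number from compound 2 to compound 3 (0.04 log units; within the scatter), concerns the group on the carbonyl carbon and stays within the scatter.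

Compound 4 `Cc1ccc(C(=O)Nc2nnc(-c3ccc(O)c(O)c3)s2)cc1` is not yet measured. It differs from compound 1 in one place: methyl in place of chloro on an aromatic carbon. Going by the values given here, no measured pair shows this exchange, so nothing in hand speaks directly to it; the only single-place step available is the one already described, and it was flat. Among the compounds with values here, with all three values within the scatter of one another and the one step flat, the expectation is a step no larger than the scatter, a 1.0-fold lower number from compound 1 to compound 4 (0.02 log units; within the scatter). Compound 4 is therefore estimated at 14000 nM, between 6000 nM and 32000 nM.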

Compound 4, half-maximal inhibitory concentration: 11800 nM
Estimate against measurement, compound 4: 1.2-fold (0.07 log units) above; the measured number falls inside the stated range.
By their numbers in this assay, from the lowest: compounds 3, 2, 4 and 1 (each within the scatter of the next).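

For the compounds shown here, at this place, on an aromatic carbon para to a large group, the step of a 1.2-fold lower number from compound 1 to compound 4 (0.09 log units; within the scatter) in this assay gives the first direct reading of methyl in place of chloro. It shows that 4-chlorophenyl and 4-methylphenyl cannot be told apart in this assay, so this single-atom exchange joins the change on the carbonyl carbon, a 1.1-fold lower number from compound 2 to compound 3 (0.04 log units; within the scatter), as a step that stays within the scatter. Nothing in hand offers a measured reason for this result.

Going by these compounds, whether an amine, a carboxylic acid or a methoxy group on the same aromatic carbon would give a step beyond the scatter remains open. On these data alone, it is also open whether methyl in place of chloro would read the same way on the core of compound 3.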